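Adding a methyl to a saturated ring carbon of compound 3

The source may hold more compounds than are shown below. What is called first, only, known or untested is meant among the compounds shown, and "the series" means these compounds.

Three compounds share one core and differ in the group on the carbonyl carbon: pyridin-4-yl in compound 1 (`O=C(NC1=NN(c2ccc(Cl)c(Cl)c2)CC1)c1ccncc1`), pyrimidin-4-yl in compound 2 (`O=C(NC1=NN(c2ccc(Cl)c(Cl)c2)CC1)c1ccncn1`) and pyrimidin-5-yl in compound 3 (`O=C(NC1=NN(c2ccc(Cl)c(Cl)c2)CC1)c1cncnc1`). In a physicochemical assay for solubility, measured as kinetic solubility, with a stated time of 1 h, at pH 7.4 (a higher number here means a more soluble compound, a lower number a less soluble compound), compound 1 gives 9000 nM, compound 2 gives 13000 nM and compound 3 gives 8000 nM. Compound 3 therefore stands within the scatter of both others, as a 1.1-fold lower number from compound 1 to compound 3 (0.05 log units; within the scatter) and a 1.6-fold lower number from compound 2 to compound 3 (0.21 log units; within the scatter) show. The remaining step, a 1.4-fold higher number from compound 1 to compound 2 (0.16 log units; within the scatter), is also within the scatter.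

Compound 4 (`C[C@H]1CN(c2ccc(Cl)c(Cl)c2)N=C1NC(=O)c1cncnc1`) is changed elsewhere: methyl in place of hydrogen on a saturated ring carbon. None of the three measured steps touches that carbon, since each one only exchanges the group on the carbonyl carbon. They give no direct measure of this change, and they show only how close these three compounds lie in this assay. No step beyond the scatter is therefore expected, and no direction can be firmly expected either. Within the data shown here, the range stays wide, as no methyl step has been measured. The expected step is a 1.2-fold lower number from compound 3 to compound 4 (0.09 log units; within the scatter), and this is an estimate only. For compound 4 the estimated value is 6500 nM, with an expected range from 2500 nM to 16000 nM.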

Compound 4, solubility: 9000 nM
The estimate for compound 4 lay 1.4-fold (0.14 log units) below the measured number; the range from low to high includes it.
By their numbers in this assay, from the lowest: compounds 3, 1, 4 and 2 (each within the scatter of the next).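

Among these compounds, the methyl on this saturated ring carbon, two ring bonds from the ring nitrogen, gives the first reading at a place that the earlier steps, all on the group on the carbonyl carbon, left untouched. In this assay, among the compounds shown here, the change gives a 1.1-fold higher number from compound 3 to compound 4 (0.05 log units; within the scatter) and so stays within the scatter, which means that this single added carbon, with no ring, no hydrogen-bond donor or acceptor and no net charge, produces no step that can be told apart from repeated measurement. Nothing measured here gives a reason for this result.

The compounds shown leave open whether a larger or different group on the same ring carbon, such as an ethyl, a longer chain, an amine or a carboxylic acid, would also stay within the scatter in this assay or would produce a real step. They also leave open whether the methyl behaves in the same way when pyridin-4-yl or pyrimidin-4-yl, rather than pyrimidin-5-yl, sits on the carbonyl carbon.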